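Amides on the shared core: a third heteroaryl variant

This account rests on a few compounds, and the source may have more. Where it says the series, first, only, none or still open, it means among the compounds named here.

Measured in a functional assay on MDA-MB-468 cells (Homo sapiens) for antiproliferative activity, read by MTT assay, with a stated time of 72 h; on this read-out higher numbers stand for weaker inhibition and lower numbers for stronger inhibition:
Compound 1 `Cc1nc(C(=O)Nc2ccc(Cl)c(-c3nnc4c(Cl)cccn34)c2)cs1` gives > 100000 nM, a limit of the assay.
Compound 2 `O=C(Nc1ccc(Cl)c(-c2nnc3c(Cl)cccn23)c1)c1ccc(Cl)cc1` gives > 100000 nM, also a limit.
Compound 3 `CS(=O)(=O)c1ccc(C(=O)Nc2ccc(Cl)c(-c3nnc4c(Cl)cccn34)c2)c(Cl)c1` gives > 100000 nM, also a limit.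

Compound 1 stands only at a limit, so no number ranks it against the others, and the limit of > 100000 nM in this assay, at which 3 of the 3 values shown sit, covers every value in hand. The step that the two limits leave unreadable from compound 1 to compound 2 therefore has no readable size. Compound 4 `O=C(Nc1ccc(Cl)c(-c2nnc3c(Cl)cccn23)c1)c1ccon1` differs from compound 1 by 1,2-oxazol-3-yl in place of 2-methyl-1,3-thiazol-4-yl on a carbonyl carbon. For the measured compounds named here, no measured step bears on this change with a readable size, so nothing beyond the scatter is expected in this assay in either direction. For compound 4 the estimate is 100000 nM (range 30000 nM to 300000 nM), most probably reported again as a limit. The step this estimate means, a number no higher from compound 1 to compound 4 (the limit leaves the size open), is expected to stay within the scatter.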

Compound 4, half-maximal inhibitory concentration: > 100000 nM
Compound 4: only a limit was reported; the forecaster's own chance of this, stated with the estimate: 85%; the middle value lies on the limit itself.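

In this assay compound 4 gives > 100000 nM, a limit and not a number. The steps from compound 1 and compound 2 to compound 4 cannot be read, and all values share one limit: the limit of > 100000 nM in this assay, at which 4 of the 4 values shown sit.

Going by these compounds, whether any group on the carbonyl carbon of the shared core gives a measurable value in this assay stays open.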